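Oxazole to Bromophenyl on an Amide: Expected Cell Toxicity

The source may report more compounds than this note shows. Statements on the series, on what has been measured and on what is new or still open speak of the compounds shown alone.

Measured compounds:
- Compound 1 `COc1ccc(-c2cnc(NC(=O)c3cnco3)n2C)cc1`: in a toxicity assay on THP-1 cells (Homo sapiens) for inhibition (on this read-out lower numbers stand for higher toxicity in this test and higher numbers for lower toxicity in this test), compound 1 reports only a limit, > 100000 nM.
- Compound 2 `Cn1c(-c2ccc(C#N)cc2)cnc1NC(=O)c1ccc(F)cc1`: in this assay compound 2 also reports only a limit, > 50000 nM.
- Compound 3 `Cn1c(-c2ccccc2)cnc1NC(=O)c1ccccc1`: in this assay compound 3 likewise reports only a limit, > 100000 nM.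

Compound 1 stands where two of the three values stand, at the limit described by the limit of > 100000 nM in this assay, at which 2 of the 3 values shown sit; the remaining value, for compound 2, sits at the other limit described by the limit of > 50000 nM in this assay, at which 1 of the 3 values shown sits. Within the data shown here, none of the three compounds gives an actual number, so no step between measured compounds can be sized, and all three read as low toxicity in this assay.

Compound 4 `COc1ccc(-c2cnc(NC(=O)c3cccc(Br)c3)n2C)cc1` differs from compound 1 in one place: 3-bromophenyl in place of 1,3-oxazol-5-yl on a carbonyl carbon. Since every measured compound sits at a limit, there is no basis for expecting a shift beyond the usual scatter; the step expected from compound 1 to compound 4 in this assay is a number no higher from compound 1 to compound 4 (the limit leaves the size open). For compound 4 the expected value in this assay is 100000 nM, within a range from 30000 nM to 300000 nM, most likely again reported only as a limit.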

Compound 4, half-maximal cytotoxic concentration: > 100000 nM
Compound 4 ended at the assay's limit; the forecaster's own chance of this, stated with the estimate: 75%; the middle value sits exactly at the limit.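

In this assay compound 4 gives only a limit, > 100000 nM. Compound 1 also gives only a limit, so the step between compound 1 and compound 4 cannot be read. The compounds shown leave open at what concentration, if any, each becomes toxic to these cells, and whether 3-bromophenyl in place of 1,3-oxazol-5-yl changes that concentration.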